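The compounds below may be only part of what the source reports. "The series", "measured", "known", "first", "only" and "open" are said of these compounds alone.

Measured compounds:
Compound 1, `COc1ccc(-c2nc3c(NC4CCCC4)ncnc3n2C)cc1`, in an assay on CHO cells for displacement of a labelled ligand from adenosine receptor A1 (Homo sapiens), read by scintillation counting, with a stated time of 3 h (on this read-out higher numbers stand for weaker inhibition and lower numbers for stronger inhibition), compound 1 gives 75 nM.
Compound 2, `Cn1c(-c2ccc(C(=O)O)cc2)nc2c(NC3CCCC3)ncnc21`, in this assay compound 2 gives 54000 nM.

Among the measured compounds shown here, compound 2 holds the highest of the two numbers so far, and its only neighbour is compound 1, from which it is separated by the single step of a 720-fold higher number from compound 1 to compound 2 (2.86 log units; beyond the scatter), a change of carboxy in place of methoxy on an aromatic carbon.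

Compound 3, `Cc1ccc(-c2nc3c(NC4CCCC4)ncnc3n2C)cc1`, has not yet been measured. It differs from compound 2 by methyl in place of carboxy on an aromatic carbon, the site being on an aromatic carbon of a six-membered aromatic ring of carbon only, para to a large group. For the measured compounds named here, the one measured step that bears on this change is the step from methoxy to carboxy, a 720-fold higher number from compound 1 to compound 2 (2.86 log units; beyond the scatter), which was large and went toward a higher number. Removing the carboxy again and putting methyl in its place undoes that group, so a large step in the opposite direction is expected in this assay, namely a 680-fold lower number from compound 2 to compound 3 (2.83 log units; beyond the scatter). Compound 3 is therefore estimated at 80 nM, with a likely range from 20 nM to 320 nM.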

Compound 3, inhibition constant: 8 nM
Beside the measured number, compound 3's estimate is 10-fold (1.00 log units) above it, and the stated range ends above it.
By their numbers in this assay, from the lowest: compound 3; then compound 1; then compound 2.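

The return from carboxy to methyl, a 6800-fold lower number from compound 2 to compound 3 (3.83 log units; beyond the scatter) in this assay, is a larger step than the one from methoxy to carboxy, a 720-fold higher number from compound 1 to compound 2 (2.86 log units; beyond the scatter), so the earlier pair had shown only part of the range at this aromatic carbon, para to a large group. The comparison of the two groups without carboxy, a 9.4-fold lower number from compound 1 to compound 3 (0.97 log units; beyond the scatter), goes beyond the scatter, so the position separates methyl from methoxy as well as either of them from carboxy, and the read-out at this site is not simply a matter of carboxy being present or absent. Nothing given here accounts for the order of these three groups.

As far as these compounds go, whether an ethyl group, a chlorine atom, an amine or a methyl ester at this carbon would give a number nearer that of compound 3 or that of compound 2 remains open. From the compounds shown here alone, all three compounds also share the rest of the core, so it is equally open whether steps of this size would hold with a different group elsewhere on it.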